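This account rests on a few compounds, and the source may have more. Where it says the series, first, only, none or still open, it means among the compounds named here.

In an ADME assay on Raji cells (Homo sapiens) for cytotoxicity, read by CellTiter-Glo and resazurin assay, with a stated time of 72 h (on this read-out lower numbers stand for an effect already at smaller amounts and higher numbers for an effect only at larger amounts of compound), compound 1 `CCOC(=O)CCCCCOc1cccc(CN(C(=O)c2ccc(-c3cccc(OC(C)C)c3)cc2)C(C)C)c1` returns only a limit, > 26000 nM. Compound 2 `CCOC(=O)CCCCCOc1cccc(CN(C(=O)c2ccc(-c3cccc(OCC)c3)cc2)C(C)C)c1` likewise gives only a limit in this assay, > 22300 nM. Compound 3 `CCOC(=O)CCCCCOc1cccc(CN(C(=O)c2ccc(-c3cccc(Br)c3)cc2)C(C)C)c1` also stands at a limit in this assay, > 26000 nM. Among the measured compounds shown here, two of the three compounds sit at the limit of > 26000 nM in this assay, at which 2 of the 3 values shown sit, and one at the limit of > 22300 nM in this assay, at which 1 of the 3 values shown sits; no compound of the series is set apart by an actual number. The steps among them are accordingly not readable: a step that the two limits leave unreadable from compound 1 to compound 2, a step that the two limits leave unreadable from compound 1 to compound 3, a step that the two limits leave unreadable from compound 2 to compound 3.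

Compound 4 `CCOC(=O)CCCCCOc1cccc(CN(C(=O)c2ccc(Br)cc2)C(C)C)c1` is not yet measured. It differs from compound 3 by bromo in place of 3-bromophenyl on an aromatic carbon. For the measured compounds named here, none of the measured steps gives a readable size, so neither a direction nor a magnitude can be drawn from them; what the three measured compounds share is that all of them sit at limits in this assay. For compound 4 the outcome expected is again a limit rather than a number, with the step expected from compound 3 to compound 4 being a step that the limit leaves unreadable from compound 3 to compound 4. Compound 4 is therefore estimated at 30000 nM in this assay, within 12000 nM to 100000 nM.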

Compound 4, half-maximal effective concentration: > 26000 nM
Compound 4 gave a limit, no number; the forecaster's own chance of this, stated with the estimate: 85%; the middle value does not contradict the limit.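

In this assay compound 4 gives only a limit, > 26000 nM, and its steps to compound 1, compound 2 and compound 3 cannot be read: the limit of > 26000 nM in this assay, at which 3 of the 4 values shown sit.

The compounds shown leave open whether bromo in place of 3-bromophenyl changes the cytotoxicity at all, since none of the four has an actual number.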